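The source may hold more compounds than are shown below. What is called first, only, known or untested is meant among the compounds shown, and "the series" means these compounds.

Working notes on the series.

Two members of the series have numbers in a functional assay on P388 cells (Mus musculus) for cytotoxicity; a lower number here means a stronger inhibitor, a higher number a weaker inhibitor. Compound 1, `COC(=O)C[C@@H]1NC(=O)[C@@H](C)NC(=O)[C@@H]2Cc3ccc(OC)c(c3)Oc3ccc(cc3)C[C@@H](C(=O)N2C)N(C)C(=O)[C@H](C)NC(=O)[C@H](Cc2ccc(OC)cc2)N(C)C1=O`, gives 41.7 nM in this assay. Compound 2, `CCCCN1C(=O)[C@@H](C)NC(=O)[C@@H]2Cc3ccc(OC)c(c3)Oc3ccc(cc3)C[C@@H](C(=O)N2C)N(C)C(=O)[C@H](C)NC(=O)[C@H](Cc2ccc(OC)cc2)N(C)C(=O)[C@@H]1C`, gives 12 nM in this assay, the lowest of the two numbers; the gap to compound 1 is beyond the scatter, so compound 2 stands as the stronger of the pair on what has been measured.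

Compound 3, `COc1ccc(C[C@H]2C(=O)N[C@@H](C)C(=O)N(C)[C@H]3Cc4ccc(cc4)Oc4cc(ccc4OC)C[C@@H](C(=O)N[C@H](C)C(=O)N(C/C=C(\C)CCC=C(C)C)[C@@H](C)C(=O)N2C)N(C)C3=O)cc1`, is the next member. The change from compound 2 is 2,6-dimethylhepta-1,5-dien-1-yl in place of propyl on a saturated chain carbon bound to an amide-type nitrogen in a ring. For the measured compounds named here, no pair of measured compounds differing in just one place is available, so the step carries no measured precedent.

With nothing measured to lean on, the step from compound 2 to compound 3 in this assay is expected to be small, with no direction beyond the scatter, which is no change at the digits printed from compound 2 to compound 3 (within the scatter). Compound 3 is therefore estimated at 12 nM in this assay, within a range from 3 nM to 45 nM.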

Compound 3, half-maximal inhibitory concentration: 49 nM
For compound 3 the middle estimate is 4.1-fold (0.61 log units) below the measured one; measured number above the stated range.
By their numbers in this assay, from the lowest: compound 2; then compounds 1 and 3 (each within the scatter of the next).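

Read as butyl to 3,7-dimethylocta-2,6-dien-1-yl, this change on a saturated chain carbon bound to an amide-type nitrogen in a ring gives a 4.1-fold higher number from compound 2 to compound 3 (0.61 log units; beyond the scatter) in this assay, the only measured step in the series so far. The position therefore responds to the group it carries, yet the step is modest, and the longer chain with its two double bonds is tolerated with a limited loss of strength. No measurement shown here bears on what lies behind this step.

The step changes chain length, branching and unsaturation together, so the contribution of each remains unresolved. A saturated chain such as 3,7-dimethyloctyl would separate length from the double bonds, while an amine or a carboxylic acid at the chain end would test whether this position accepts anything other than hydrocarbon.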